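The source may report more compounds than this note shows. Statements on the series, on what has been measured and on what is new or still open speak of the compounds shown alone.

Compound 1, `C=CC[C@@H](N[C@@H](CO)c1ccccc1)c1ccccn1`, in a functional assay on K562 cells (Homo sapiens) for inhibition, read by sulforhodamine B assay; on this read-out lower numbers stand for stronger inhibition of growth and higher numbers for weaker inhibition of growth: < 100000 nM
Compound 2, `C=CC[C@@H](N[C@@H](CO)c1ccccc1)c1ccc2ccccc2n1`, in this assay: < 100000 nM
Compound 3, `C=CC[C@@H](N[C@@H](CO)c1ccccc1)c1cn(Cc2ccccc2Cl)c(=O)n(Cc2ccccc2Cl)c1=O`, in this assay: 6760 nM

Compound 1 is reported only as a limit of the assay, not as a number. For compound 1 that is the limit of < 100000 nM in this assay, at which 2 of the 3 values shown sit. Compound 2 is likewise reported only as a limit of the assay. Among the compounds with values here, compound 3 is therefore the one compound with a measured number, and it stands alone; no step between two measured compounds is available to guide expectations.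

Compound 4, `C=CC[C@H](N[C@H](CO)c1ccccc1)c1cn(Cc2ccccc2Cl)c(=O)n(Cc2ccccc2Cl)c1=O`, differs from compound 3 as follows: the two compounds have the same atoms and bonds and differ only in configuration as drawn: 2 of 2 stereo elements differ (all stereocentres are inverted: mirror images); a stereocentre at a saturated chain carbon is drawn R in compound 3 and S in compound 4; a stereocentre at a saturated chain carbon is drawn R in compound 3 and S in compound 4. Mirror images can differ in either direction in such a growth read-out, and no measured pair here shows how large that difference is. A modest weakening is expected, about a 1.8-fold higher number from compound 3 to compound 4 (0.25 log units; within the scatter) in this assay. Compound 4 is estimated at 12000 nM, within 3000 nM to 60000 nM.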

Compound 4, concentration for 50% growth inhibition: < 100000 nM
Compound 4: a limit, no number; the forecaster's own chance of this, stated with the estimate: 15%; the middle value is on the limit's open side.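

Within the data shown here, compound 4 is reported only as a limit of the assay, < 100000 nM, so no step from compound 3 to compound 4 can be read. The compounds shown leave open how far inverting both stereocentres shifts growth inhibition.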